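Methyl for Hydrogen at the Sulfur-Bound Carbon of Compound 2

The source may hold more compounds than are shown below. What is called first, only, known or untested is meant among the compounds shown, and "the series" means these compounds.

Compound 1 `Cc1cn2cccc(OCc3ccccc3)c2n1` reaches 62% in a functional assay on the whole organism with Rattus norvegicus as the target, with a stated time of 4 h, at a dose of 40 mg/kg by the intraperitoneal route; on this read-out lower numbers stand for less inhibition and higher numbers for more inhibition at the one dose given (going by the name of the read-out). Among the compounds with values here, compound 2 `CSCc1c(C)nc2c(OCc3ccccc3)cccn12` gives 29%, the lowest of the two numbers measured so far; the step of a number 33 percentage points lower from compound 1 to compound 2 (beyond the scatter) came with a (methylsulfanyl)methyl group added on an aromatic carbon. Compound 3 `CCSCc1c(C)nc2c(OCc3ccccc3)cccn12` differs from compound 2 by methyl in place of hydrogen on a saturated chain carbon bound to a sulfur. Within the data shown here, no measured step concerns such a change on a saturated chain carbon bound to a sulfur, so the single known step offers no direct guide, and a step within the usual scatter is expected: a number 1 percentage points higher from compound 2 to compound 3 (within the scatter). Compound 3 is therefore expected to give about 30%, within 10% to 50%.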

Compound 3, a percentage reported as inhibition, in the whole organism at one dose (the size of the read-out at that dose, not a potency): 36%
For compound 3 the middle estimate is 6 percentage points below the measured one; measured number inside the range.
By their numbers in this assay, from the lowest: compounds 2 and 3 (each within the scatter of the next); then compound 1.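

In this assay, going from methylsulfanyl to ethylsulfanyl gives a number 7 percentage points higher from compound 2 to compound 3 (within the scatter), so this added methyl on a saturated chain carbon bound to a sulfur makes no readable difference. The (ethylsulfanyl)methyl group still gives a number 26 percentage points lower from compound 1 to compound 3 (beyond the scatter) and so, like (methylsulfanyl)methyl, it stands with a number beyond the scatter from that of compound 1. Nothing measured here explains either step. Open, from the compounds shown here alone, is whether a propyl chain on the sulfur would stay at this level, and whether an amine in place of the sulfur-bearing group would come closer to compound 1 at 62%.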